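This account rests on a few compounds, and the source may have more. Where it says the series, first, only, none or still open, it means among the compounds named here.

Measured in a functional assay on HCT-116 cells (Homo sapiens) for antiproliferative activity, read by CCK-8 assay, with a stated time of 72 h; a higher number here means a weaker inhibitor, a lower number a stronger inhibitor:
- compound 1 `Cc1cc(Nc2cc(N3CCN(C)CC3)nc(Nc3ccc([N+](=O)[O-])cc3)n2)n[nH]1`: 1630 nM
- compound 2 `Cc1cc(Nc2cc(N3CCN(C)CC3)nc(Nc3cccc([N+](=O)[O-])c3)n2)n[nH]1`: 1820 nM
- compound 3 `Cc1cc(Nc2cc(N3CCN(C)CC3)nc(Nc3cccc(Cl)c3)n2)n[nH]1`: 736 nM

Compound 3 gives the lowest number of the three, making it the strongest inhibitor so far. Compound 4 `Cc1cc(Nc2cc(N3CCN(C)CC3)nc(Nc3ccc(C#N)cc3)n2)n[nH]1` has 4-cyanophenyl in place of 3-chlorophenyl on a nitrogen on an aromatic ring. Among the compounds with values here, no measured compound carries 4-cyanophenyl, so only indirect guidance exists. Replacing 4-nitrophenyl with 3-nitrophenyl gave a 1.1-fold higher number from compound 1 to compound 2 (0.05 log units; within the scatter). Replacing 4-nitrophenyl with 3-chlorophenyl gave a 2.2-fold lower number from compound 1 to compound 3 (0.35 log units; beyond the scatter), and chloro in place of nitro gave a 2.5-fold lower number from compound 2 to compound 3 (0.39 log units; beyond the scatter). Taking compound 1 at 1630 nM as the closest measured comparison, a modest rise in this assay is expected, though this remains untested. The expected change is a 1.8-fold higher number from compound 3 to compound 4 (0.25 log units; within the scatter). For compound 4 the estimated value is 1300 nM, with an expected range from 500 nM to 3300 nM.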

Compound 4, half-maximal inhibitory concentration: 650 nM
For compound 4 the middle estimate is 2.0-fold (0.30 log units) above the measured one; the measured number falls inside the stated range.
By their numbers in this assay, from the lowest: compounds 4 and 3 (each within the scatter of the next); then compounds 1 and 2 (each within the scatter of the next).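

In this assay, 4-cyanophenyl in place of 3-chlorophenyl gives a 1.1-fold lower number from compound 3 to compound 4 (0.05 log units; within the scatter) on this nitrogen, so a nitrile-bearing ring sits level with the chloro compound. Cyano in place of nitro on the same aromatic carbon gives a 2.5-fold lower number from compound 1 to compound 4 (0.40 log units; beyond the scatter) and shows that the group at that carbon can change the number without any move around the ring, while 4-cyanophenyl in place of 3-nitrophenyl gives a 2.8-fold lower number from compound 2 to compound 4 (0.45 log units; beyond the scatter) in the same direction. No measured evidence here accounts for these differences. On these data alone, whether an amine or a carboxylic acid on this ring would do as well remains open.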